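Linker Variation from Urea to Amide to Cyclopropyl Amide

The compounds below may be only part of what the source reports. "The series", "measured", "known", "first", "only" and "open" are said of these compounds alone.

compound 1 `O=C(NCc1cccnc1)Nc1ccc(CN2C(=O)c3ccccc3C2=O)cc1`: 100 nM
compound 2 `O=C(CCc1cccnc1)Nc1ccc(CN2C(=O)c3ccccc3C2=O)cc1`: > 10000 nM

In a functional assay on A2780 cells (Homo sapiens) for antiproliferative activity, read by CellTiter-Glo, with a stated time of 4 days (on this read-out higher numbers stand for weaker inhibition and lower numbers for stronger inhibition), compound 1 gives 100 nM. Compound 2 sits at the limit of > 10000 nM in this assay, at which 1 of the 2 values shown sits, a limit of this assay and not a number. For the measured compounds named here, the single measured step, an at least 100-fold higher number from compound 1 to compound 2 (2.00 log units; beyond the scatter), is large. Compound 3 `O=C(Nc1ccc(CN2C(=O)c3ccccc3C2=O)cc1)[C@@H]1C[C@H]1c1cccnc1` differs from compound 2 by 2-(pyridin-3-yl)cyclopropyl in place of 2-(pyridin-3-yl)ethyl on a carbonyl carbon. Going by the values given here, no measured step covers this exchange, and the amide carbonyl of compound 2 is kept. Compound 3 is therefore expected to remain weak, with an estimated 10000 nM (range 2500 nM to 30000 nM). The expected step of a number no higher from compound 2 to compound 3 (the limit leaves the size open) would not go beyond the scatter.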

Compound 3, half-maximal inhibitory concentration: > 2500 nM
Compound 3: only a limit was reported (the forecaster's own chance of this, stated with the estimate: 60%); the middle value does not contradict the limit.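

Compound 3 in this assay is reported only as a limit: the limit of > 2500 nM in this assay, at which 1 of the 3 values shown sits.
Even so, the 2-(pyridin-3-yl)cyclopropyl group in place of ((pyridin-3-yl)methyl)amino gives an at least 25-fold higher number from compound 1 to compound 3 (1.39 log units; beyond the scatter), so the cyclopropyl amide, like the ethyl amide, does not match the urea. The two limits leave the step between compound 2 and compound 3 unreadable, so no difference between the cyclopropyl and the ethyl group can be stated.

From the compounds shown here alone, it remains open whether the opposite cyclopropyl stereoisomer would differ. Going by these compounds, it is equally open whether a ((pyridin-3-yl)methyl)oxy group on the carbonyl carbon would keep the activity of compound 1.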